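Swapping the oxirane for fluorine on a stable aryl core

The compounds below may be only part of what the source reports. "The series", "measured", "known", "first", "only" and "open" are said of these compounds alone.

Compound 1 `C=Cc1cc(C(F)(F)F)cc(C(F)(F)F)c1`: > 50 h
Compound 2 `FC(F)(F)c1cc(C2CO2)cc(C(F)(F)F)c1`: > 50 h

In an ADME assay for pharmacokinetics, read by LC-MS, in phosphate buffer, with a stated time of 72 h, at pH 7.4, tested at 250 uM (on this read-out higher numbers stand for a longer-lived compound and lower numbers for a shorter-lived compound), compound 1 returns > 50 h, which is a limit of the assay rather than a number. In this assay compound 2 likewise returns > 50 h, again a limit and not a number. Compound 2 therefore stands at the limit of > 50 h in this assay, at which 2 of the 2 values shown sit, and because of the limit of > 50 h in this assay, at which 2 of the 2 values shown sit, the step that the two limits leave unreadable from compound 1 to compound 2 cannot be read in either size or direction.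

Compound 3 `Fc1cc(C(F)(F)F)cc(C(F)(F)F)c1` has not yet been measured. It differs from compound 2 in one place: fluoro in place of oxiran-2-yl on an aromatic carbon, the new group sitting meta to two trifluoromethyl groups. For the measured compounds named here, the only measured step, a step that the two limits leave unreadable from compound 1 to compound 2, touches the same aromatic carbon of the shared core, but it yields no size at all. With both measured compounds at the limit, no step beyond the scatter can be called for from the data, and the expectation is that compound 3 also sits beyond the limit. Compound 3 is accordingly estimated at 60 h, with a range from 35 h to 150 h. The step that the limit leaves unreadable from compound 2 to compound 3 that this estimate implies is expected to stay within the scatter.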

Compound 3, half-life: > 50 h
Compound 3: no number, only a limit (the forecaster's own chance of this, stated with the estimate: 85%); the middle value is on the limit's open side.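

Compound 3 gives > 50 h in this assay as a limit and not a number. The steps among compound 1, compound 2 and compound 3 therefore cannot be read in size or direction: the limit of > 50 h in this assay, at which 3 of the 3 values shown sit. The compounds shown leave open how long each one actually lasts and whether vinyl, oxiran-2-yl and fluoro differ at all.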